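The source may report more compounds than this note shows. Statements on the series, on what has been measured and on what is new or still open speak of the compounds shown alone.

Compound 1 `N#CCC(=O)N/N=C1\C(=O)Nc2ccc(S(=O)(=O)N3CCOCC3)cc21` and compound 2 `O=C1Nc2ccc(S(=O)(=O)N3CCOCC3)cc2/C1=N/Nc1ccccc1` share a core that carries a morpholine sulfonyl group and differ only at the hydrazone nitrogen. In a functional assay on HCT-116 cells (Homo sapiens) for cytotoxicity, read by sulforhodamine B assay, with a stated time of 24 h (a lower number here means a stronger inhibitor, a higher number a weaker inhibitor), compound 1 gives 10300 nM, and compound 2 gives 10500 nM. Compound 1 holds the lower of the two numbers, but the step of a 1.0-fold higher number from compound 1 to compound 2 (0.01 log units; within the scatter) means the two compounds cannot be told apart on this evidence.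

The unmeasured compound 3 `O=C1Nc2ccc(S(=O)(=O)N3CCOCC3)cc2/C1=N/c1ccc(Cl)cc1` differs from compound 1 in one place: 4-chlorophenyl in place of ((cyanomethyl)carbonyl)amino on a double-bonded nitrogen. This change differs in kind from the phenyl-for-(cyanomethyl)carbonyl swap seen between compound 1 and compound 2, since here the whole ((cyanomethyl)carbonyl)amino group departs and an aromatic ring is joined directly to the double-bonded nitrogen. Among the compounds with values here, the only measured step, a 1.0-fold higher number from compound 1 to compound 2 (0.01 log units; within the scatter), shows the numbers in this assay tolerating a swap at the same region without moving beyond the scatter. Within the data shown here, on that single precedent, and with no measured step of this exact kind, the step of a 1.0-fold lower number from compound 1 to compound 3 (0.01 log units; within the scatter) is expected to stay within the scatter. Compound 3 is therefore estimated at 10000 nM in this assay, with a range from 3500 nM to 30000 nM.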

Compound 3, half-maximal inhibitory concentration: 24300 nM
Beside the measured number, compound 3's estimate is 2.4-fold (0.39 log units) below it; the measured number falls inside the stated range.
By their numbers in this assay, from the lowest: compounds 1 and 2 (each within the scatter of the next); then compound 3.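

In this assay this position proves sensitive to what stands on the double-bonded nitrogen. Whereas a 1.0-fold higher number from compound 1 to compound 2 (0.01 log units; within the scatter) showed no separation, the change to 4-chlorophenyl gives a 2.4-fold higher number from compound 1 to compound 3 (0.37 log units; beyond the scatter) and, with anilino as the group that leaves, also gives a 2.3-fold higher number from compound 2 to compound 3 (0.36 log units; beyond the scatter) and so moves the number modestly in the weaker direction. Among these three compounds, the two that keep an amino nitrogen on the double-bonded nitrogen stay within the scatter of each other despite carrying very different groups on it, while compound 3, with its aromatic ring joined directly, stands apart, and nothing shown gives a reason for this difference.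

Compound 3 differs from compound 2 both by the loss of the amino nitrogen and by the gain of chlorine, which leaves open which of the two changes carries the step; a 4-chloroanilino group on the same nitrogen would separate them. Also open, going by these compounds, is how a plain phenyl, a 4-methoxyphenyl or a 4-carboxyphenyl group joined directly to that nitrogen would read.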